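This account rests on a few compounds, and the source may have more. Where it says the series, first, only, none or still open, it means among the compounds named here.

Measured compounds:
compound 1 `CC(C)CCc1nc2c([nH]1)N1C(=N[C@@H]3CCC[C@@H]31)N(C)C2=O` gives 14 nM
compound 2 `CCCC(CCC)c1nc2c([nH]1)N1C(=N[C@@H]3CCC[C@@H]31)N(C)C2=O` gives 60 nM

In an assay on isolated protein for inhibition of dual specificity calcium/calmodulin-dependent 3',5'-cyclic nucleotide phosphodiesterase 1A (Bos taurus) (on this read-out lower numbers stand for stronger inhibition and higher numbers for weaker inhibition), compound 2 holds the highest of the two numbers, compound 1 being the nearest, with a 4.3-fold higher number from compound 1 to compound 2 (0.63 log units; beyond the scatter). Compound 3 `CCCCCCCCc1nc2c([nH]1)N1C(=N[C@@H]3CCC[C@@H]31)N(C)C2=O` differs from compound 2 by octyl in place of 1-propylbutyl on an aromatic carbon. Within the data shown here, only the step from compound 1 to compound 2 bears on this change, as it also exchanges one chain for another on the same aromatic carbon, and it was modest in size. Among the measured compounds shown here, no measured pair covers an unbranched chain. A modest step is therefore expected, leaning toward a lower number, a 2.4-fold lower number from compound 2 to compound 3 (0.38 log units; beyond the scatter). Compound 3 is estimated at 25 nM, ranging from 8 nM to 80 nM.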

Compound 3, half-maximal inhibitory concentration: 33 nM
Estimate against measurement, compound 3: 1.3-fold (0.12 log units) below; the range from low to high includes it.
By their numbers in this assay, from the lowest: compound 1; then compounds 3 and 2 (each within the scatter of the next).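

In this assay the step of a 1.8-fold lower number from compound 2 to compound 3 (0.26 log units; within the scatter) stays within the scatter, so on this aromatic carbon octyl and 1-propylbutyl are not told apart, although one chain is unbranched and the other branched. The a 2.4-fold higher number from compound 1 to compound 3 (0.37 log units; beyond the scatter) lies beyond the scatter, so compound 1 keeps its edge over the unbranched chain as well as the branched one. Nothing available explains either step.

The compounds shown leave open how a shorter chain such as ethyl would read here, and whether an amine or a carboxylic acid at the chain end would change the number.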